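The source may report more compounds than this note shows. Statements on the series, on what has been measured and on what is new or still open speak of the compounds shown alone.

Of the compounds shown here, three built on one shared core have been measured in a functional assay on HL-60 cells (Homo sapiens) for inhibition, read by MTT assay, with a stated time of 72 h; on this read-out lower numbers stand for stronger inhibition and higher numbers for weaker inhibition. Compound 1 `Cc1nc(-c2ccccc2)c(C(=O)N2CCN(c3cccc(C)c3C)CC2)o1` gives 35 nM in this assay. Compound 3 `CCc1nc(-c2ccc(F)cc2)c(C(=O)N2CCN(c3cccc(Cl)c3)CC2)o1` gives 169 nM in this assay, a number higher than that of compound 1 by a margin beyond the usual scatter. Compound 2 `COc1cccc(N2CCN(C(=O)c3oc(C(F)(F)F)nc3-c3ccc(F)cc3)CC2)c1` is reported in this assay as "not active" (no number reported), with no number attached. Of the two numbers available, compound 1 thus holds the lower one, and the third entry offers nothing to compare.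

Compound 4 `Cc1nc(-c2ccccc2)c(C(=O)N2CCN(c3cc(Cl)cc(Cl)c3)CC2)o1` has not yet been measured. It differs from compound 1 in a single place: 3,5-dichlorophenyl in place of 2,3-dimethylphenyl on an amine nitrogen in a ring. Going by the values given here, no pair of measured compounds differs in only this place, so the data give no direct guide to the size of such a step; compounds 1 and 3 differ in several places at once. Among the compounds with values here, the step from compound 1 to compound 4 is expected to be modest and towards weaker inhibition, a 2.9-fold higher number from compound 1 to compound 4 (0.46 log units; beyond the scatter), because compound 3 gives 169 nM while being the only other measured compound that bears chlorine. Compound 4 is therefore estimated at 100 nM, with a range from 30 nM to 400 nM.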

Compound 4, half-maximal inhibitory concentration: 41.8 nM
Compound 4: middle estimate off by 2.4-fold (0.38 log units), on the high side, and the stated range covers the measured number.
By their numbers in this assay, from the lowest: compounds 1 and 4 (each within the scatter of the next); then compound 3.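

In this assay, replacing 2,3-dimethylphenyl with 3,5-dichlorophenyl on the amine nitrogen in the ring is a step too small to separate the two compounds (a 1.2-fold higher number from compound 1 to compound 4 (0.08 log units; within the scatter)). Going by these compounds alone, this is the first direct reading of a change at this position: on the core of compound 1, an aromatic ring carrying two chlorine atoms performs on a par with one carrying two methyl groups, something compound 3 could not show, since it differs from both in several places at once. Nothing measured here offers an explanation for this result.

The two groups differ both in their atoms and in where those atoms sit on the ring, so this one step cannot separate those two changes, and 3,5-dimethylphenyl on the same core would be needed to tell them apart. Going by these compounds, it also remains open whether this position would accept a ring bearing a carboxylic acid or an amine, and whether the result would hold with the other substituents found on the core of compound 3.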